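The compounds below may be only part of what the source reports. "The series", "measured", "known", "first", "only" and "open" are said of these compounds alone.

Of the compounds shown here, two have so far been measured in an assay on isolated protein for inhibition of Amine oxidase [flavin-containing] A (Homo sapiens), read by fluorescence and Amplex Red, with stated times of 15 min and 20 min; on this read-out higher numbers stand for weaker inhibition and lower numbers for stronger inhibition. Compound 1, `CC(C)=CCc1c(O)cc(/C=C/c2ccc3c(c2)[C@H](c2cc(O)c(CC=C(C)C)c(O)c2)[C@@H](c2ccc(O)cc2)O3)cc1O`, gives 2600 nM, while compound 2, `CC(C)=CCc1c(O)cc([C@@H](Oc2ccc(/C=C/c3cc(O)c4c(c3)OC(C)(C)CC4)cc2)[C@@H](C)c2ccc(O)cc2)cc1O`, gives 18900 nM. Compound 2 thus stands at the higher of the two numbers, meaning weaker inhibition, and its distance from compound 1 lies beyond the scatter of repeated measurements. Compound 3, `CO[C@@H](c1ccc(O)cc1)[C@H](Oc1ccc(/C=C/c2cc(O)c3c(c2)OC(C)(C)CC3)cc1)c1cc(O)c(CC=C(C)C)c(O)c1`, has not yet been measured. It differs from compound 2 in a single place: methoxy in place of methyl on a saturated chain carbon bound to an aromatic carbon and a saturated chain carbon. Among the compounds with values here, no measured pair in this set shows that same change, so its effect cannot be read from the numbers at hand. With nothing pointing either way, the expected step in this assay is small, a 1.1-fold higher number from compound 2 to compound 3 (0.02 log units; within the scatter), and not clearly beyond the scatter in either direction. Compound 3 is therefore expected to give about 20000 nM, with a likely range from 8000 nM to 50000 nM.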

Compound 3, half-maximal inhibitory concentration: 10600 nM
The estimate for compound 3 lay 1.9-fold (0.28 log units) above the measured number, within the range that was stated.
By their numbers in this assay, from the lowest: compound 1; then compounds 3 and 2 (each within the scatter of the next).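

In this assay, within the data shown here, methoxy in place of methyl on a saturated chain carbon bound to an aromatic carbon and a saturated chain carbon gives a 1.8-fold lower number from compound 2 to compound 3 (0.25 log units; within the scatter), the first comparison here of compounds that differ in one place. At this position, the swap adds an oxygen and a hydrogen-bond acceptor, yet the two numbers cannot be told apart from the scatter of repeated measurements, so this pair shows no measurable effect of the change. Nothing at hand explains this outcome. Still open, from the compounds shown here alone, is whether another group on this carbon, such as an amine, a carboxylic acid or a longer chain, would move the number beyond the scatter. This single pair also cannot show whether methoxy in place of methyl would behave the same way on the core of compound 1.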